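Bromine on the Anilino Ring: Expected Cytotoxicity Outcome

The source may hold more compounds than are shown below. What is called first, only, known or untested is meant among the compounds shown, and "the series" means these compounds.

Measured compounds:
compound 1 `Cc1ccc(-c2nn(-c3ccccc3)cc2CNc2ccccc2)cc1`: > 100000 nM
compound 2 `Cc1ccc(NCc2cn(-c3ccccc3)nc2-c2ccc(Cl)cc2)cc1`: > 100000 nM

In an ADME assay on MT4 cells (Homo sapiens) for cytotoxicity, read by MTT assay, with a stated time of 96 h (a lower number here means that less compound is tolerated, a higher number that more compound is tolerated), compound 1 gives > 100000 nM, which is a limit of the assay rather than a number. Compound 2 gives > 100000 nM, also a limit. Both values therefore rest at the limit of > 100000 nM in this assay, at which 2 of the 2 values shown sit, so compound 1 stands at the tolerated end of what this assay can report.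

Compound 3 `Cc1ccc(-c2nn(-c3ccccc3)cc2CNc2ccc(Br)cc2)cc1` differs from compound 1 by bromo in place of hydrogen on an aromatic carbon. Within the data shown here, no measured step is available, so in this assay no change beyond the scatter is expected. Compound 3 is expected to give 100000 nM, ranging from 50000 nM to 200000 nM. The step of a number no higher from compound 1 to compound 3 (the limit leaves the size open) is expected to be flat.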

Compound 3, half-maximal cytotoxic concentration: > 100000 nM
Compound 3 was reported as a limit (the forecaster's own chance of this, stated with the estimate: 80%); the middle value lies on the limit itself.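

Compound 1 and compound 3 are both reported only as a limit in this assay, so the effect of the bromo on cytotoxicity cannot be read: the limit of > 100000 nM in this assay, at which 3 of the 3 values shown sit.

The compounds shown leave open what concentration of any of them would harm these cells.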